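Hydroxy in Place of Fluoro on the Aromatic Ring

This account rests on a few compounds, and the source may have more. Where it says the series, first, only, none or still open, it means among the compounds named here.

Of the compounds shown here, three sharing one core have been measured in an assay for inhibition of Dihydrofolate reductase (Bos taurus), at pH 7.20; a higher number here means a more potent compound, by a factor of ten per unit of this negative logarithm, a lower number a less potent compound. Compound 1 `CC1(C)N=C(N)N=C(N)N1c1ccccc1N` gives 4.58. Compound 2 `CSc1ccccc1N1C(N)=NC(N)=NC1(C)C` gives 3.91. Compound 3 `CC1(C)N=C(N)N=C(N)N1c1ccccc1F` gives 5.41, the highest of the three: a number 0.83 log units higher from compound 1 to compound 3 (beyond the scatter), and a number 1.50 log units higher from compound 2 to compound 3 (beyond the scatter). Compound 4 `CC1(C)N=C(N)N=C(N)N1c1ccccc1O` has not yet been measured; it differs from compound 3 by hydroxy in place of fluoro on an aromatic carbon. The step in which fluoro replaced amino, a number 0.83 log units higher from compound 1 to compound 3 (beyond the scatter), bears most on this, for amino and hydroxy are alike in being hydrogen-bonding groups where fluoro is not; undoing that kind of change points downward. Compound 2, with methylsulfanyl, is a weaker guide, though a number 1.50 log units higher from compound 2 to compound 3 (beyond the scatter) also shows fluoro ahead. A modest decrease is therefore expected for compound 4, a number 0.61 log units lower from compound 3 to compound 4 (beyond the scatter). Compound 4 is estimated at 4.8 in this assay, within a range from 4.2 to 5.4.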

Compound 4, logarithm of the reciprocal of the active concentration, log(1/C): 4.18
Estimate against measurement, compound 4: 0.62 log units above; the measured number lies below the stated range.
By their numbers in this assay, from the lowest: compounds 2 and 4 (each within the scatter of the next); then compound 1; then compound 3.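

Hydroxy proves a poor stand-in for fluoro on this aromatic carbon, ortho to a large group, in this assay: the change gives a number 1.23 log units lower from compound 3 to compound 4 (beyond the scatter) and shows that fluoro's lead does not carry over to this group. Hydroxy does not match amino here either, since the change between them gives a number 0.40 log units lower from compound 1 to compound 4 (beyond the scatter) and the two groups cannot be treated as interchangeable at this position. Methylsulfanyl and hydroxy cannot be told apart, as the change gives a number 0.27 log units higher from compound 2 to compound 4 (within the scatter), which leaves fluoro clearly ahead of all three other groups on this carbon.

From the compounds shown here alone, whether a chloro or methoxy group at the same place would stay close to compound 3 or fall towards compound 4 remains open. No measurement available here accounts for the size of these steps.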